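This account rests on a few compounds, and the source may have more. Where it says the series, first, only, none or still open, it means among the compounds named here.

Working notes on the series, read in a physicochemical assay for lipophilicity, at pH 7.4; a higher number here means a more lipophilic compound, a lower number a more polar compound. Compound 1 `CS(=O)(=O)N1C[C@H](C(=O)Nc2ccc(Cl)cc2)[C@@H](C(=O)Nc2ccc(-n3ccccc3=O)cc2F)C1` gives 2.17, compound 2 `COc1ccc(NC(=O)[C@H]2CN(S(C)(=O)=O)C[C@@H]2C(=O)Nc2ccc(-n3ccccc3=O)cc2F)cc1` gives 1.19 and compound 3 `COc1ccc(NC(=O)[C@H]2CN(S(C)(=O)=O)C[C@@H]2C(=O)Nc2ccc(-n3ccccc3=O)cc2F)cc1Cl` gives 1.9. Compound 3 lies within the scatter of compound 1, the step being a number 0.27 log units lower from compound 1 to compound 3 (within the scatter), and well clear of compound 2, at a number 0.71 log units higher from compound 2 to compound 3 (beyond the scatter). Compound 4 `CS(=O)(=O)N1C[C@H](C(=O)Nc2ccc(Cl)c(F)c2)[C@@H](C(=O)Nc2ccc(-n3ccccc3=O)cc2F)C1` has 4-chloro-3-fluorophenyl in place of 3-chloro-4-methoxyphenyl on an amide-type nitrogen. The nearest guide is the exchange of chloro for methoxy, a number 0.98 log units lower from compound 1 to compound 2 (beyond the scatter). For the measured compounds named here, no measured step covers fluoro. A modest rise is therefore expected, the estimated step being a number 0.40 log units higher from compound 3 to compound 4 (beyond the scatter). Compound 4 is estimated at 2.3, with an expected range of 2 to 2.6.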

Compound 4, distribution coefficient: 2.37
The estimate for compound 4 lay 0.07 log units below the measured number; measured number inside the range.
By their numbers in this assay, from the lowest: compound 2; then compounds 3, 1 and 4 (each within the scatter of the next, the first and the last beyond it).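

In this assay, for the compounds shown here, the aryl group on the amide-type nitrogen spans the widest range yet: 4-chloro-3-fluorophenyl in place of 4-methoxyphenyl gives a number 1.18 log units higher from compound 2 to compound 4 (beyond the scatter) as the largest step so far, and in place of 3-chloro-4-methoxyphenyl gives a number 0.47 log units higher from compound 3 to compound 4 (beyond the scatter) as a smaller one. Fluoro in place of hydrogen gives a number 0.20 log units higher from compound 1 to compound 4 (within the scatter) and so leaves no readable shift on the 4-chlorophenyl group. No measurement shown accounts for these steps. Still open, from the compounds shown here alone, is how a carboxylic acid or a dimethylamino group on this aryl ring would read in this assay and whether fluoro without chloro would read the same.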